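The source may report more compounds than this note shows. Statements on the series, on what has been measured and on what is new or still open speak of the compounds shown alone.

In a functional assay on MKN-45 cells (Homo sapiens) for inhibition, read by CCK-8 assay, with a stated time of 24 h (on this read-out higher numbers stand for weaker inhibition and lower numbers for stronger inhibition), three compounds with a shared core have been measured. Compound 1 `Cc1ccc(-n2cc(-c3ccc(/C=C4\C(=O)Nc5ccc(F)cc54)cc3)nn2)cc1` gives 34600 nM, compound 2 `O=C1Nc2ccc(F)cc2/C1=C/c1ccc(-c2cn(-c3ccccc3F)nn2)cc1` gives 8510 nM, and compound 3 `O=C1Nc2ccc(F)cc2/C1=C/c1ccc(-c2cn(-c3cccc(F)c3)nn2)cc1` gives 8190 nM. Compound 3 therefore shares the low end of this small set with compound 2, and the two cannot be told apart.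

The next compound, compound 4 `O=C1Nc2ccc(F)cc2/C1=C/c1ccc(-c2cn(-c3ccc(F)cc3)nn2)cc1`, has 4-fluorophenyl in place of 3-fluorophenyl on an aromatic nitrogen of a five-membered aromatic ring with 3 nitrogen (4-fluorophenyl in place of 3-fluorophenyl on an aromatic nitrogen). Going by the values given here, the closest precedent is a 1.0-fold lower number from compound 2 to compound 3 (0.02 log units; within the scatter), also a swap of one fluorophenyl for another, and it stays within the scatter. Larger, though still modest, are a 4.1-fold lower number from compound 1 to compound 2 (0.61 log units; beyond the scatter) and a 4.2-fold lower number from compound 1 to compound 3 (0.63 log units; beyond the scatter), where 4-methylphenyl leaves.

Among the compounds with values here, no measured compound carries the new group, so the range must stay wide, but no step beyond the scatter is expected in this assay. The expected change is a 1.1-fold higher number from compound 3 to compound 4 (0.04 log units; within the scatter). For compound 4 the estimated value is 9000 nM, with an expected range of 3500 nM to 25000 nM.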

Compound 4, half-maximal inhibitory concentration: > 20000 nM
Compound 4: a limit, no number (the forecaster's own chance of this, stated with the estimate: 5%); middle value at least 2.2-fold (0.34 log units) away from the limit.
By their numbers in this assay, from the lowest: compounds 3 and 2 (each within the scatter of the next); then compound 1.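

In this assay, compound 4 is reported only as a limit, not a number: the limit of > 20000 nM in this assay, at which 1 of the 4 values shown sits. Compounds 2 and 3 could not be told apart, so the place of the fluorine seemed not to matter, but 4-fluorophenyl, with the same atoms joined differently, brings an at least 2.4-fold higher number from compound 3 to compound 4 (0.38 log units; beyond the scatter) and an at least 2.3-fold higher number from compound 2 to compound 4 (0.37 log units; beyond the scatter), so among these three compounds the outcome does depend on where the single fluorine sits on the phenyl group. The step between compound 1 and compound 4 cannot be read.

From the compounds shown here alone, how much weaker compound 4 really is stays open, since only a lower bound on the gap is known. Also open, going by these compounds, is how a phenyl group carrying an amine, a methoxy group or a carboxylic acid, rather than fluorine, would fare on this aromatic nitrogen.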